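The source may hold more compounds than are shown below. What is called first, only, known or untested is meant among the compounds shown, and "the series" means these compounds.

Working notes on the series.

The shared core carries an amide-linked phenyl ring whose substituent varies. Compound 1 `CC(C)(C)c1ccc(NC(=O)c2csc(Cc3c(Cl)cccc3Cl)n2)cc1` gives 300 nM in an assay on CHO cells, read by calcium flux; a higher number here means a weaker inhibitor, a lower number a stronger inhibitor. Compound 2 `CCc1ccc(NC(=O)c2csc(Cc3c(Cl)cccc3Cl)n2)cc1` gives 1450 nM in this assay. Compound 3 `O=C(Nc1ccccc1)c1csc(Cc2c(Cl)cccc2Cl)n1` reaches only a limit of this assay, > 4000 nM, and not a number (the limit of > 4000 nM in this assay, at which 1 of the 3 values shown sits).

Among the two numbers shown, compound 2 stands highest; its nearest neighbour is compound 1, and the step of a 4.8-fold higher number from compound 1 to compound 2 (0.68 log units; beyond the scatter) lies beyond the scatter. The steps of an at least 13-fold higher number from compound 1 to compound 3 (1.12 log units; beyond the scatter) and an at least 2.7-fold higher number from compound 2 to compound 3 (0.44 log units; beyond the scatter) point the same way: every shortening of the group on this aromatic carbon has raised the number.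

Compound 4 `COc1ccc(NC(=O)c2csc(Cc3c(Cl)cccc3Cl)n2)cc1` is not yet measured. It differs from compound 2 by methoxy in place of ethyl on an aromatic carbon. The measured steps all concern trimming or removing this group; here one two-heavy-atom group is swapped for another of the same count, so the direction those steps set is only weakly informative. A step smaller than an at least 2.7-fold higher number from compound 2 to compound 3 (0.44 log units; beyond the scatter) is expected, if any beyond the scatter, most likely toward a somewhat higher number.

Compound 4 is therefore expected to give 2000 nM in this assay, in a range from 800 nM to 5000 nM, a step of a 1.4-fold higher number from compound 2 to compound 4 (0.14 log units; within the scatter) that is estimated to stay near the scatter.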

Compound 4, half-maximal inhibitory concentration: > 4000 nM
Compound 4: only a limit was reported (the forecaster's own chance of this, stated with the estimate: 25%); middle value at least 2.0-fold (0.30 log units) away from the limit.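

Compound 4 reaches only a limit of this assay, > 4000 nM, and not a number. The earlier steps shown here only trimmed or removed the group on this aromatic carbon, whereas 4-ethylphenyl to 4-methoxyphenyl keeps the heavy-atom count of the group and still gives an at least 2.7-fold higher number from compound 2 to compound 4 (0.44 log units; beyond the scatter), so at this place the number does not follow that count alone: methoxy brings an oxygen and a hydrogen-bond acceptor where ethyl has neither. Set against the tert-butyl group, the same change gives an at least 13-fold higher number from compound 1 to compound 4 (1.12 log units; beyond the scatter), which places methoxy on the weak side of the series, while the step between the two limit compounds cannot be read.

As far as these compounds go, whether an amine, a carboxylic acid or a longer chain such as propyl on this aromatic carbon would bring the number back toward that of compound 1 or compound 2 stays open, as does whether the effect of the oxygen would persist with the tert-butyl group's carbon count restored in a larger ether such as tert-butoxy. How far methoxy and hydrogen lie from each other also stays open, and the series offers no reading of it: the limit of > 4000 nM in this assay, at which 2 of the 4 values shown sit.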